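The compounds below may be only part of what the source reports. "The series", "measured", "known", "first", "only" and "open" are said of these compounds alone.

Measured so far:
- compound 1, `c1ccc(-c2cc(OCC3CCNCC3)cnc2-c2ccccc2)cc1`, 46300 nM
- compound 2, `Cc1ccc(-c2ncc(OCC3CCNCC3)cc2-c2ccc(CO)cc2)cc1`, 62600 nM
- compound 3, `Brc1ccc(-c2ncc(OCC3CCNCC3)nc2-c2ccc(Br)cc2)cc1`, 5700 nM

In an assay on isolated protein for inhibition of histone acetyltransferase p300 (Homo sapiens), read by scintillation counting, with stated times of 10 min and 30 min (a higher number here means a weaker inhibitor, a lower number a stronger inhibitor), compound 3 gives 5700 nM, the lowest of the three numbers. Compound 1 gives 46300 nM, and compound 2 gives 62600 nM; both of these differences from compound 3 lie beyond the usual scatter, so compound 3 is the strongest inhibitor of the three. No two of these compounds differ in only one place, so nothing can be said about any single structural step among them.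

Compound 4, `Brc1ccc(-c2ncc(OCC3CCNC3)nc2-c2ccc(Br)cc2)cc1`, has not yet been measured. It differs from compound 3 in one place: pyrrolidin-3-yl in place of piperidin-4-yl on a saturated chain carbon bound to an oxygen on an aromatic ring. Going by the values given here, nothing among the measured compounds shows what such a change does in this assay, so the expectation rests on the small size of the change alone. The step from compound 3 to compound 4 is expected to be small, a 1.2-fold higher number from compound 3 to compound 4 (0.09 log units; within the scatter), within or barely beyond the scatter. Compound 4 is therefore estimated at 7000 nM, with a range from 2500 nM to 20000 nM.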

Compound 4, half-maximal inhibitory concentration: > 10000 nM
Compound 4: no number, only a limit; the forecaster's own chance of this, stated with the estimate: 10%; middle value at least 1.4-fold (0.15 log units) away from the limit.
By their numbers in this assay, from the lowest: compound 3; then compounds 1 and 2 (each within the scatter of the next).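

In this assay compound 4 gives > 10000 nM, which is a limit of the assay and not a number. Going by these compounds alone, this is the first comparison in the set that changes only one place, the group on a saturated chain carbon bound to an oxygen on an aromatic ring: pyrrolidin-3-yl in place of piperidin-4-yl gives an at least 1.7-fold higher number from compound 3 to compound 4 (0.24 log units; that floor lies within the scatter), so the five-membered ring brings no gain, but a real loss is not established. The true size of the step stays hidden, as the reading ends at a limit: the limit of > 10000 nM in this assay, at which 1 of the 4 values shown sits.

The compounds shown leave open how other groups at this place would read, such as an azetidine ring or an open-chain amine. They also leave open whether the same ring change would give a similar step on the cores of compound 1 and compound 2.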